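The source may hold more compounds than are shown below. What is called first, only, known or untested is meant among the compounds shown, and "the series" means these compounds.

Measured in a functional assay on Hep 3B2 cells (Homo sapiens) for antiproliferative activity, read by MTT assay, with a stated time of 24 h, tested at 1.23 ug/mL; on this read-out higher numbers stand for a stronger effect at the one concentration tested and lower numbers for a weaker effect:
compound 1, `CCOc1ccc2nc(C(=O)Nc3c(F)cc(-c4cccc(F)c4)cc3F)c(C)c(O)c2c1`, gives 1.03%;
compound 2, `Cc1c(C(=O)Nc2c(F)cc(-c3cccc(F)c3)cc2F)nc2ccc(C(F)(F)F)cc2c1O`, gives 15.3%;
compound 3, `COc1ccc2nc(C(=O)Nc3ccc(-c4ccccc4)cc3)c(C)c(O)c2c1`, gives 14.2%.

Compound 3 stands second highest of the three numbers, within the scatter of compound 2 and beyond the scatter above compound 1. Compound 4, `Cc1c(C(=O)Nc2ccc(-c3ccccc3)cc2)nc2ccccc2c1O`, differs from compound 3 by hydrogen in place of methoxy on an aromatic carbon. Within the data shown here, the only measured step at this place on the shared core is a number 14.3 percentage points higher from compound 1 to compound 2 (beyond the scatter), an exchange of one group for another, not a removal; it shows that a change here can move the read-out modestly. Among the measured compounds shown here, no measured step removes an ethoxy or methoxy group outright. For compound 4 a step within the scatter, or a small one in either direction, is expected, a number 4.2 percentage points lower from compound 3 to compound 4 (within the scatter). Compound 4 is estimated at 10%, range 0% to 25%.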

Compound 4, a percentage reported as inhibition, at one concentration (the size of the read-out at that concentration, not a potency): 14.3%
The estimate for compound 4 lay 4.3 percentage points below the measured number, and the stated range covers the measured number.
By their numbers in this assay, from the lowest: compound 1; then compounds 3, 4 and 2 (each within the scatter of the next).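

In this assay, hydrogen in place of methoxy on this aromatic carbon gives a number 0.1 percentage points higher from compound 3 to compound 4 (within the scatter) and leaves the read-out unchanged within the scatter. For this pair the methoxy group is therefore not needed to hold the read-out, whereas a number 14.3 percentage points higher from compound 1 to compound 2 (beyond the scatter) showed that exchanging ethoxy for trifluoromethyl can move it. Nothing available accounts for either step. From the compounds shown here alone, whether an amine or a carboxylic acid on this carbon would move the read-out remains open. So does whether hydrogen in place of ethoxy in compound 1 would leave it unchanged.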